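Diacetylamino replacing methylamino on the shared core

A few compounds are considered here, and "the series" means these few. Any claim that something is new, unique, unknown or untested is made for them only; others in the source may bear on it.

Among the compounds with values here, compound 2 `CNc1c(C#N)[n+]([O-])c2cc(Cl)ccc2[n+]1[O-]` stands highest of the two numbers so far in a functional assay on Ehrlich cells (Mus musculus) for cytotoxicity, read by trypan blue exclusion, with a stated time of 2 h, tested at 50 ug/mL (on this read-out lower numbers stand for a stronger effect and higher numbers for a weaker effect at the one concentration tested), where compound 2 gives 81.4%. Its nearest neighbour is compound 1 `N#Cc1c(N)[n+]([O-])c2ccc(Cl)cc2[n+]1[O-]`, which in this assay gives 43.5%; the step of a number 37.9 percentage points higher from compound 1 to compound 2 (beyond the scatter) lies beyond the scatter.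

Compound 3 `CC(=O)N(C(C)=O)c1c(C#N)[n+]([O-])c2cc(Cl)ccc2[n+]1[O-]` is not yet measured. It differs from compound 2 by diacetylamino in place of methylamino on an aromatic carbon, on an aromatic carbon of the shared core, next to the ring nitrogen and ortho to a cyano group. Within the data shown here, the one measured step bears on it only loosely: it also changed what sits on the nitrogen attached to that carbon, and it was large, as a number 37.9 percentage points higher from compound 1 to compound 2 (beyond the scatter) shows. Diacetylamino carries no hydrogen-bond donor; the expectation is a further move in the direction of the step of a number 37.9 percentage points higher from compound 1 to compound 2 (beyond the scatter), or none beyond the scatter, rather than a return toward compound 1. A step of a number 4.6 percentage points higher from compound 2 to compound 3 (within the scatter) is therefore expected. Compound 3 is estimated at 86%, within a range from 62% to 100%.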

Compound 3, a percentage reported as activity, at one concentration (the size of the read-out at that concentration, not a potency): 1.3%
The estimate for compound 3 lay 84.7 percentage points above the measured number, and the stated range ends above it.
By their numbers in this assay, from the lowest: compound 3; then compound 1; then compound 2.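

Notes on the nitrogen substituent: in this assay, this position on an aromatic carbon of the shared core is not confined to weakening the effect, since diacetylamino in place of methylamino gives a number 80.1 percentage points lower from compound 2 to compound 3 (beyond the scatter), and diacetylamino in place of amino gives a number 42.2 percentage points lower from compound 1 to compound 3 (beyond the scatter), which leaves compound 3 with the strongest effect of the three at the one concentration tested. Substitution at this nitrogen therefore has no one-way trend: methylamino gave a number 37.9 percentage points higher from compound 1 to compound 2 (beyond the scatter), while diacetylamino, with 7 heavy atoms, moves the number the opposite way, so compound 2 goes against any ordering by the size of the group. Nothing available bears on why the diacetylamino compound stands so low in this read-out.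

The compounds shown leave open whether both acetyl groups are needed, which a single acetylamino group on the same carbon would test, and whether a carbonyl is needed at all, which dimethylamino would test. Also open, on these data alone, is whether longer acyl chains, such as dipropionylamino, hold the low number of compound 3 in this assay.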